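A few compounds are considered here, and "the series" means these few. Any claim that something is new, unique, unknown or untested is made for them only; others in the source may bear on it.

Measured compounds, with their values in a functional assay on HepG2 cells (Homo sapiens) for antiproliferative activity, read by MTT assay, with a stated time of 72 h; a lower number here means a stronger inhibitor, a higher number a weaker inhibitor:

- Compound 1 `O=C1O[C@H]([C@@H](O)Cn2cc(-c3cccc(O)c3)nn2)C(OCc2ccccc2)=C1OCc1ccccc1`: compound 1 gives 62700 nM.
- Compound 2 `COc1ccccc1-c1cn(C[C@H](O)[C@H]2OC(=O)C(OCc3ccccc3)=C2OCc2ccccc2)nn1`: compound 2 gives > 100000 nM, which is a limit of this assay and not a number.
- Compound 3 `O=C1O[C@H]([C@@H](O)Cn2cc(C3CC3)nn2)C(OCc2ccccc2)=C1OCc1ccccc1`: compound 3 gives 38100 nM.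

Compound 3 holds the lowest of the two numbers in this assay; its nearest neighbour is compound 1, and the gap between the two, a 1.6-fold lower number from compound 1 to compound 3 (0.22 log units; within the scatter), lies within the scatter. The step of an at least 2.6-fold lower number from compound 2 to compound 3 (0.41 log units; beyond the scatter) is larger, though the value of compound 2 is only a limit (the limit of > 100000 nM in this assay, at which 1 of the 3 values shown sits). The step of an at least 1.5-fold higher number from compound 1 to compound 2 (0.20 log units; that floor lies within the scatter) rests on that same limit.

Compound 4 `O=C1O[C@H]([C@@H](O)Cn2cc(-c3cc(F)cc(F)c3)nn2)C(OCc2ccccc2)=C1OCc1ccccc1` differs from compound 3 by 3,5-difluorophenyl in place of cyclopropyl on an aromatic carbon. Both measured steps run from an aryl group to cyclopropyl and end at a lower number; the step to compound 4 runs the other way, from cyclopropyl to an aryl group. Compound 4 is therefore expected to give a higher number in this assay, a step of about a 1.7-fold higher number from compound 3 to compound 4 (0.23 log units; within the scatter), modest in size, since the two measured steps were small to at least modest. The estimate for compound 4 is 65000 nM, in the range 30000 nM to 140000 nM, with a fair chance that the assay reports only a limit.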

Compound 4, half-maximal inhibitory concentration: 11600 nM
Beside the measured number, compound 4's estimate is 5.6-fold (0.75 log units) above it, outside the stated range (below it).
By their numbers in this assay, from the lowest: compound 4; then compounds 3 and 1 (each within the scatter of the next). At a limit, above all of these: compound 2.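

In this assay, going by these compounds alone, the aromatic carbon of the five-membered aromatic ring with 3 nitrogen does not simply favour cyclopropyl over an aryl group, as the earlier compounds could have suggested: a 3.3-fold lower number from compound 3 to compound 4 (0.52 log units; beyond the scatter). The aryl groups also separate from one another, a 5.4-fold lower number from compound 1 to compound 4 (0.73 log units; beyond the scatter), so the identity of the aryl group matters here, and compound 1 goes against any reading that an aryl group alone lowers the number, since it lies within the scatter of compound 3. The step of an at least 8.6-fold lower number from compound 2 to compound 4 (0.93 log units; beyond the scatter) extends this picture, but it rests on compound 2, whose value is a limit and not a number: the limit of > 100000 nM in this assay, at which 1 of the 4 values shown sits.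

The compounds shown leave open whether the lower number of compound 4 depends on its fluorines or on the phenyl ring itself, a question that unsubstituted phenyl, a chlorophenyl or an aminophenyl at the same carbon would address. They also leave open how a longer alkyl chain, such as n-butyl, would compare with cyclopropyl at this carbon, and the two benzyl ethers stay the same throughout, so nothing here speaks to them.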